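The source may report more compounds than this note shows. Statements on the series, on what has been measured and on what is new or still open speak of the compounds shown alone.

Compounds measured:
Compound 1, `O=C(C(Nc1ccccc1F)c1ccc(C(F)(F)F)cc1)N1CCCC1c1ccccc1F`: 7 nM
Compound 2, `O=C(C(Nc1ccccc1F)c1ccc(C(F)(F)F)cc1)N1CCCC1c1cccc(F)c1`: 9 nM
Compound 3, `O=C(C(Nc1ccccc1F)c1ccc(C(F)(F)F)cc1)N1CCCC1c1cccnc1`: 7 nM

In an assay on HEK293 cells for antagonist activity at transient receptor potential M8 protein (Canis lupus familiaris), read by fluorescence and calcium flux, with a stated time of 5 min (on this read-out lower numbers stand for stronger inhibition and higher numbers for weaker inhibition), compound 3 stands level with compound 1 at the digits shown, the two together giving the lowest numbers of the three, and the gap to compound 2 is small: a 1.3-fold lower number from compound 2 to compound 3 (0.11 log units; within the scatter). Compound 4, `O=C(C(Nc1ccccc1F)c1ccc(C(F)(F)F)cc1)N1CCCC1c1ccncc1`, differs from compound 3 by pyridin-4-yl in place of pyridin-3-yl on a saturated ring carbon. Going by the values given here, the steps that bear on this are the earlier exchanges of the aromatic group at the same saturated ring carbon, a 1.3-fold higher number from compound 1 to compound 2 (0.11 log units; within the scatter) and no change at the digits printed from compound 1 to compound 3 (within the scatter), neither of which moved the read-out beyond the scatter. The same is therefore expected here: the step of a 1.1-fold higher number from compound 3 to compound 4 (0.06 log units; within the scatter) is estimated to lie within the scatter. Compound 4 is expected to give 8 nM, with a range from 4 nM to 16 nM.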

Compound 4, half-maximal inhibitory concentration: 19 nM
Beside the measured number, compound 4's estimate is 2.4-fold (0.38 log units) below it; the whole stated range lies below it.
By their numbers in this assay, from the lowest: compounds 1, 3 and 2 (each within the scatter of the next); then compound 4.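

At this saturated ring carbon, this assay now separates two groups with the same atoms, joined differently: pyridin-4-yl in place of pyridin-3-yl gives a 2.7-fold higher number from compound 3 to compound 4 (0.43 log units; beyond the scatter). Pyridin-4-yl also stands apart from both fluorophenyl groups, with a 2.1-fold higher number from compound 2 to compound 4 (0.32 log units; beyond the scatter) and a 2.7-fold higher number from compound 1 to compound 4 (0.43 log units; beyond the scatter), each beyond the scatter, whereas the exchanges among the first three compounds all stayed within it. No evidence is available on what lies behind these steps. The compounds shown leave open how pyridin-2-yl or an aminopyridine would read at this carbon.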